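Furan-bearing series: methylamino to ethylamino at the acid stage

The source may report more compounds than this note shows. Statements on the series, on what has been measured and on what is new or still open speak of the compounds shown alone.

Measured so far in an assay on CHO cells for displacement of a labelled ligand from adenosine receptor A3 (Homo sapiens); a higher number here means a weaker inhibitor, a lower number a stronger inhibitor:
compound 1 `O=C(Nc1ncc(C(=O)O)c2nc(-c3ccco3)nn12)NC1CCCCC1` gives 59400 nM
compound 2 `CCOC(=O)c1cnc(NCCOC)n2nc(-c3ccco3)nc12` gives 105 nM
compound 3 `CNc1ncc(C(=O)O)c2nc(-c3ccco3)nn12` gives 15900 nM

Compound 3 stands second highest of the three numbers in this assay: compound 1 is the nearest, and compound 2 lies far lower; compound 2 differs from compound 3 in two places, so its value is only shown, not read as a step. For the measured compounds named here, the one measured step, a 3.7-fold lower number from compound 1 to compound 3 (0.57 log units; beyond the scatter), trims a large group to methyl on the ring nitrogen.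

Compound 4 `CCNc1ncc(C(=O)O)c2nc(-c3ccco3)nn12` differs from compound 3 by methyl in place of hydrogen on a saturated chain carbon bound to a nitrogen on an aromatic ring. Going by the values given here, no measured step touches this place, so the step of a 1.4-fold lower number from compound 3 to compound 4 (0.16 log units; within the scatter) is expected to stay within the scatter. Compound 4 is estimated at 11000 nM, range 3500 nM to 35000 nM.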

Compound 4, inhibition constant: 480 nM
The estimate for compound 4 lay 23-fold (1.36 log units) above the measured number, and the stated range ends above it.
By their numbers in this assay, from the lowest: compound 2; then compound 4; then compound 3; then compound 1.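

In this assay, methylamino to ethylamino gives a 33-fold lower number from compound 3 to compound 4 (1.52 log units; beyond the scatter), so this place on the saturated chain carbon responds strongly to a single added methyl. Ethyl in place of cyclohexylcarbamoyl gives a 120-fold lower number from compound 1 to compound 4 (2.09 log units; beyond the scatter), which shows that the substituent on this nitrogen can shift the number widely while the carboxylic acid stays in place. The data offer no explanation for the size of the methyl step.

As far as these compounds go, whether a longer chain such as propyl extends the trend remains open. So does whether ethylamino gives a similar step alongside an ethyl ester in place of the carboxylic acid.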